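Sulfonyl aryl variation on a shared anilino-pyrimidine core

A few compounds are considered here, and "the series" means these few. Any claim that something is new, unique, unknown or untested is made for them only; others in the source may bear on it.

Working notes on a small series that keeps one core and changes only the aryl group on the sulfonyl sulfur. Compound 1 `Cc1ccc(NS(=O)(=O)c2ccc(Cl)cc2)cc1Nc1nccc(-c2cccnc2)n1` carries a 4-chlorophenyl group there; in a functional assay on MDA-MB-231 cells (Homo sapiens) for cytotoxicity, read by MTT assay, with a stated time of 24 h (on this read-out lower numbers stand for stronger inhibition and higher numbers for weaker inhibition), compound 1 gives 7790 nM. Compound 2 `Cc1ccc(NS(=O)(=O)c2ccc(-c3ccccc3)cc2)cc1Nc1nccc(-c2cccnc2)n1` replaces the chloro by phenyl, and compound 2 gives 8000 nM, so that a 1.0-fold higher number from compound 1 to compound 2 (0.01 log units; within the scatter). Compound 3 `Cc1ccc(NS(=O)(=O)c2ccc3ccccc3c2)cc1Nc1nccc(-c2cccnc2)n1` carries naphthalen-2-yl, and compound 3 gives 8310 nM. The step of a 1.1-fold higher number from compound 1 to compound 3 (0.03 log units; within the scatter) and the step of a 1.0-fold higher number from compound 2 to compound 3 (0.02 log units; within the scatter) are both small; the three numbers sit together, and compound 3 is no further from compound 2 or compound 1 than the scatter allows.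

Compound 4 `Cc1ccc(NS(=O)(=O)c2cnc3ccccc3c2)cc1Nc1nccc(-c2cccnc2)n1` is the next member and has not yet been run. The change is quinolin-3-yl in place of naphthalen-2-yl on a sulfonyl sulfur. Among the compounds with values here, all three measured steps concern the same sulfonyl aryl position and none of them moved the number beyond the scatter; no measured step introduces a ring nitrogen, so that part of the change has no precedent here. On this basis no step beyond the scatter is expected in this assay, in either direction, and the expected step is a 1.0-fold lower number from compound 3 to compound 4 (0.00 log units; within the scatter). For compound 4 the estimate is 8300 nM, with a range from 4000 nM to 17000 nM.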

Compound 4, half-maximal inhibitory concentration: 7310 nM
Beside the measured number, compound 4's estimate is 1.1-fold (0.06 log units) above it; measured number inside the range.
By their numbers in this assay, from the lowest: compounds 4, 1, 2 and 3 (each within the scatter of the next).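

Within the data shown here, the quinolin-3-yl group is the first to bring a ring nitrogen and a hydrogen-bond acceptor onto the sulfonyl sulfur, and in this assay this change gives a 1.1-fold lower number from compound 3 to compound 4 (0.06 log units; within the scatter). The comparisons with the other two aryl groups read the same way, with a 1.1-fold lower number from compound 2 to compound 4 (0.04 log units; within the scatter) and a 1.1-fold lower number from compound 1 to compound 4 (0.03 log units; within the scatter), so all four compounds lie within the scatter of one another in this assay, and the position has so far tolerated a hetero atom in the ring as well as the chloro and phenyl groups. No supporting data bear on this outcome, so the flat result stands as an observation without an explanation.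

The compounds shown leave open whether the number at this position can be moved at all, for instance by a saturated group such as cyclohexyl, a longer alkyl chain, or an aryl ring carrying an amine or a carboxylic acid. They also leave open whether the flat result holds for changes on the shared core, since every compound here keeps that core unchanged.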